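Lengthening the Chain From Compound 2 to Compound 3

The compounds below may be only part of what the source reports. "The series", "measured", "known", "first", "only" and "open" are said of these compounds alone.

In a functional assay on A549 cells (Homo sapiens) for cytotoxicity, read by MTT assay, with a stated time of 72 h (a lower number here means a stronger inhibitor, a higher number a weaker inhibitor), compound 1 `CC[S+]([O-])CCCCN=C=S` gives 10200 nM and compound 2 `CCC[S+]([O-])CCCCN=C=S` gives 10700 nM so the two stand level within the usual scatter. Compound 3 `CCCC[S+]([O-])CCCCN=C=S` differs from compound 2 by methyl in place of hydrogen on a saturated chain carbon, three bonds along the chain from a sulfur and in words this is methyl in place of hydrogen on a saturated chain carbon, three bonds along the chain from a sulfur. Going by the values given here, only one measured step bears on this, the same swap two bonds along the chain from a sulfur: a 1.0-fold higher number from compound 1 to compound 2 (0.02 log units; within the scatter) and it lay within the scatter. One step is thin evidence, but no change beyond the scatter is expected in this assay here. The estimated step is a 1.1-fold lower number from compound 2 to compound 3 (0.03 log units; within the scatter) and it stays within the scatter. Compound 3 is expected at 10000 nM with a likely range from 5000 nM to 20000 nM in this estimate.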

Compound 3, half-maximal inhibitory concentration: 9560 nM
The estimate for compound 3 lay 1.0-fold (0.02 log units) above the measured number; low and high end bracket the measured number.
By their numbers in this assay, from the lowest: compounds 3, 1 and 2 (each within the scatter of the next).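

In this assay, adding a further carbon, this time three bonds along the chain from the sulfur, again gives no change that can be told apart (a 1.1-fold lower number from compound 2 to compound 3 (0.05 log units; within the scatter)). The two added carbons taken together also stay within the scatter (a 1.1-fold lower number from compound 1 to compound 3 (0.03 log units; within the scatter)), so compounds 1, 2 and 3 stand level across ethyl, propyl and butyl. Nothing available explains this flat result. Still open, from the compounds shown here alone, is whether a longer chain, such as octyl, would stay level, and whether an amine or a carboxylic acid in place of butyl would move the number beyond the scatter.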